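A Bromofluoropyridine Swap in a Flat Series

The compounds below may be only part of what the source reports. "The series", "measured", "known", "first", "only" and "open" are said of these compounds alone.

In a functional assay on MDA-MB-436 cells (Homo sapiens) for antiproliferative activity, read by MTT assay, with a stated time of 48 h (a higher number here means a weaker inhibitor, a lower number a stronger inhibitor), compound 1 `C=CS(=O)(=O)N1CCN(c2ncnc3sc(-c4ccccc4)cc23)CC1` gives 21100 nM, compound 2 `C=CS(=O)(=O)N1CCN(c2ncnc3sc(-c4ccc(OC)cc4)cc23)CC1` gives 28400 nM, and compound 3 `C=CS(=O)(=O)N1CCN(c2ncnc3sc(-c4cccc5ncccc45)cc23)CC1` gives 25900 nM. Compound 3 therefore stands within the scatter of both others. Compound 4 `C=CS(=O)(=O)N1CCN(c2ncnc3sc(-c4cc(Br)cnc4F)cc23)CC1` has 5-bromo-2-fluoropyridin-3-yl in place of quinolin-5-yl on an aromatic carbon, next to the ring sulfur: 5-bromo-2-fluoropyridin-3-yl in place of quinolin-5-yl on an aromatic carbon. The measured changes to this group were all small: a 1.3-fold higher number from compound 1 to compound 2 (0.13 log units; within the scatter), a 1.2-fold higher number from compound 1 to compound 3 (0.09 log units; within the scatter), and a 1.1-fold lower number from compound 2 to compound 3 (0.04 log units; within the scatter). For the measured compounds named here, none of the measured compounds carries bromine or fluorine, so the forecast remains uncertain. No change beyond the scatter is expected in this assay, with an estimated 1.2-fold lower number from compound 3 to compound 4 (0.07 log units; within the scatter). Compound 4 is expected to give 22000 nM. Its estimated range runs from 10000 nM to 45000 nM.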

Compound 4, half-maximal inhibitory concentration: 28400 nM
Estimate against measurement, compound 4: 1.3-fold (0.11 log units) below; measured number inside the range.
By their numbers in this assay, from the lowest: compounds 1, 3, 2 and 4 (each within the scatter of the next).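

Bromine and fluorine now appear at this position, on an aromatic carbon next to the ring sulfur, yet in this assay the swap gives a 1.1-fold higher number from compound 3 to compound 4 (0.04 log units; within the scatter) and the comparisons with the other compounds give no change at the digits printed from compound 2 to compound 4 (within the scatter) and a 1.3-fold higher number from compound 1 to compound 4 (0.13 log units; within the scatter). All four aryl groups shown, including this smaller 5-bromo-2-fluoropyridin-3-yl, therefore sit within the scatter of one another. No available evidence explains this flat result. On these data alone, whether an amine or a carboxylic acid on the aromatic ring at this position would shift the number remains open.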